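This account rests on a few compounds, and the source may have more. Where it says the series, first, only, none or still open, it means among the compounds named here.

Measured so far:
Compound 1 `Cn1c(N)c(-c2nc3ccccc3[nH]2)c2nc(C#N)c(C#N)nc21` — > 50000 nM in an ADME assay on HEK293 cells (Homo sapiens) for cytotoxicity, read by MTT assay, with a stated time of 48 h; on this read-out lower numbers stand for stronger inhibition and higher numbers for weaker inhibition
Compound 2 `CCN(CC)CCn1c(N)c(-c2nc3ccccc3[nH]2)c2nc(C#N)c(C#N)nc21` — 12200 nM in this assay

In this assay compound 1 gives > 50000 nM, and this is a limit of the assay rather than a number. Compound 2 gives 12200 nM. For the measured compounds named here, the one step measured so far runs an at least 4.0-fold lower number from compound 1 to compound 2 (0.61 log units; beyond the scatter), and its size can only be stated as a bound because compound 1 sits at the limit of > 50000 nM in this assay, at which 1 of the 2 values shown sits.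

Compound 3 `CCN(CC)CCCn1c(N)c(-c2nc3ccccc3[nH]2)c2nc(C#N)c(C#N)nc21` has not yet been measured in this assay. Against compound 1 it differs by 2-(diethylamino)ethyl in place of hydrogen on a saturated chain carbon bound to an aromatic nitrogen. Going by the values given here, the chain that enters is one carbon longer than the one that enters in compound 2, and it is attached at the same place, so the step from compound 1 to compound 2 is the only measured step that bears on it. That step lowered the number beyond the scatter, and a lowering of similar size is expected here too, though the limit on compound 1 leaves the exact size open. Compound 3 is therefore estimated at 12000 nM, within 3500 nM to 40000 nM, an expected step of an at least 4.1-fold lower number from compound 1 to compound 3 (0.61 log units; beyond the scatter).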

Compound 3, half-maximal inhibitory concentration: 7870 nM
For compound 3 the middle estimate is 1.5-fold (0.18 log units) above the measured one, and the stated range covers the measured number.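

With 2-(diethylamino)ethyl in place of hydrogen on a saturated chain carbon bound to an aromatic nitrogen, this assay shows an at least 6.3-fold lower number from compound 1 to compound 3 (0.80 log units; beyond the scatter), so the lower number seen with compound 2 now appears with a second chain ending in diethylamino at this same place. The two chains themselves stand apart by only a 1.6-fold lower number from compound 2 to compound 3 (0.19 log units; within the scatter), which means that compound 2 and compound 3 cannot be ranked, and across these two lengths the exact chain length shows no readable effect on the number in this assay. The size of the step from the hydrogen-bearing side remains a bound, because compound 1 gives a limit of the assay rather than a number: the limit of > 50000 nM in this assay, at which 1 of the 3 values shown sits.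

The compounds shown leave open whether the diethylamino end or the chain alone goes with the lower number, a question that a chain of similar length ending in a hydroxyl group or a plain alkyl chain would address. They also leave open what happens with a longer chain, or with a ring amine such as morpholine or piperidine in place of diethylamino.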